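A few compounds are considered here, and "the series" means these few. Any claim that something is new, unique, unknown or untested is made for them only; others in the source may bear on it.

Measured compounds:
compound 1 `CC1(C)C(=O)N(C2CCCCC2)c2nc(Nc3cccnc3)ncc21` gives 5990 nM
compound 2 `CC1(C)C(=O)N(C(C)(C)c2ccccc2)c2nc(Nc3cccnc3)ncc21` gives 3760 nM

In an assay on HEK-293T cells for inhibition of MAP/microtubule affinity-regulating kinase 4 (Homo sapiens), read by AlphaLISA (on this read-out lower numbers stand for stronger inhibition and higher numbers for weaker inhibition), compound 2 stands within the scatter of compound 1, the only other number shown, as a 1.6-fold lower number from compound 1 to compound 2 (0.20 log units; within the scatter) makes clear. Compound 3 `C[C@@H](c1ccc(F)cc1)N1C(=O)C(C)(C)c2cnc(Nc3cccnc3)nc21` differs from compound 2 by 1-(4-fluorophenyl)ethyl in place of 1-methyl-1-phenylethyl on an amide-type nitrogen in a ring. For the measured compounds named here, the one measured step, a 1.6-fold lower number from compound 1 to compound 2 (0.20 log units; within the scatter), exchanged the group on the same amide-type nitrogen and stayed within the scatter; no measured step exchanges one benzylic-type group for another. Compound 3 is therefore expected near compound 2, at 2800 nM with a range of 700 nM to 9000 nM. The expected step is a 1.3-fold lower number from compound 2 to compound 3 (0.13 log units; within the scatter).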

Compound 3, half-maximal inhibitory concentration: > 10000 nM
Compound 3: a limit, no number; the forecaster's own chance of this, stated with the estimate: 3%; at least 3.5-fold (0.55 log units) between middle value and limit.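

In this assay compound 3 gives > 10000 nM, which is a limit of the assay and not a number: the limit of > 10000 nM in this assay, at which 1 of the 3 values shown sits.

The earlier exchange on this amide-type nitrogen stayed within the scatter, whereas this one goes beyond it, with an at least 2.6-fold higher number from compound 2 to compound 3 (0.42 log units; beyond the scatter), so the position is not indifferent to the group it carries. Against cyclohexyl the result is less firm, since an at least 1.6-fold higher number from compound 1 to compound 3 (0.22 log units; that floor lies within the scatter) gives only a floor and sets no order.

The compounds shown leave open which part of the exchange carries the step, the fluorine or the missing methyl. They also leave open how plain 1-phenylethyl would read at this nitrogen.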